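Clearance notes: a rearranged hydroxy-dimethylpiperidine on compound 1

This account rests on a few compounds, and the source may have more. Where it says the series, first, only, none or still open, it means among the compounds named here.

Measured so far in an ADME assay on cells (Hepatocyte, Rattus norvegicus, strain Wistar) for pharmacokinetics, read by LC-MS, with a stated time of 90 min, tested at 1 uM; on this read-out higher numbers stand for fast clearance and lower numbers for slow clearance:
- compound 1 `COc1cc(C(=O)N2CC[C@@H](O)C(C)(C)C2)cc2nc(NCc3cccc(Cl)c3)oc12`: 51.7 mL/min/kg
- compound 2 `COc1cc(C(=O)N2CCC(O)C(C)C2)cc2nc(NC3(c4cccc(Cl)c4)CC3)oc12`: 46.7 mL/min/kg

Compound 1 stands at 51.7 mL/min/kg and compound 2 at 46.7 mL/min/kg, so the two lie within the scatter of each other and both numbers sit in one band. The next compound is compound 3 `COc1cc(C(=O)N2CC(C)C(O)CC2C)cc2nc(NCc3cccc(Cl)c3)oc12`, which keeps the core of compound 1 and changes only the amide group: 4-hydroxy-2,5-dimethylpiperidin-1-yl in place of 4-hydroxy-3,3-dimethylpiperidin-1-yl on a carbonyl carbon. The atoms are the same, joined differently. Among the measured compounds shown here, no pair of measured compounds differing in one place is available, so no measured step guides this change. No step beyond the scatter is expected in this assay, and the expectation rests on compound 1 at 51.7 mL/min/kg. The expected change is a 1.1-fold lower number from compound 1 to compound 3 (0.05 log units; within the scatter). For compound 3 the estimated clearance is 46 mL/min/kg, with an expected range of 27 mL/min/kg to 72 mL/min/kg.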

Compound 3, clearance: 56.7 mL/min/kg
The estimate for compound 3 lay 1.2-fold (0.09 log units) below the measured number; measured number inside the range.
By their numbers in this assay, from the lowest: compounds 2, 1 and 3 (each within the scatter of the next).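

In this assay, putting 4-hydroxy-2,5-dimethylpiperidin-1-yl in place of 4-hydroxy-3,3-dimethylpiperidin-1-yl on a carbonyl carbon gives a 1.1-fold higher number from compound 1 to compound 3 (0.04 log units; within the scatter), the only one-place comparison among the compounds shown. With the same atoms joined differently, this rearrangement on the core of compound 1 does not separate the two compounds on this read-out, although the group that leaves has a defined stereocentre and the group that enters has none. No measured data bear on the reason for this result.

On these data alone, whether any group at this position can shift clearance beyond the scatter remains open, since a morpholine amide or a piperidine carrying a carboxylic acid would test a different kind of group. How the individual stereoisomers of compound 3 behave also remains unresolved.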